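The source may report more compounds than this note shows. Statements on the series, on what has been measured and on what is new or still open speak of the compounds shown alone.

Measured compounds:
compound 1 `COc1ccc(CNc2nc3cc(N)cc(N)c3nc2-c2ccccc2)cc1OC`: 38900 nM
compound 2 `Nc1cc(N)c2nc(-c3ccccc3)c(NCc3ccc(F)cc3)nc2c1`: 3160 nM
compound 3 `COc1ccc(CNc2nc3cc(N)cc(N)c3nc2-c2ccccc2)cc1`: 26300 nM

In a functional assay on U-251 cells (Homo sapiens) for inhibition, read by sulforhodamine B assay, with a stated time of 48 h (a higher number here means a weaker inhibitor of growth, a lower number a stronger inhibitor of growth), compound 2 gives the lowest of the three numbers, with 3160 nM; its nearest neighbour is compound 3, separated by an 8.3-fold higher number from compound 2 to compound 3 (0.92 log units; beyond the scatter), and the furthest is compound 1, separated by a 12-fold lower number from compound 1 to compound 2 (1.09 log units; beyond the scatter). The step from compound 1 to compound 3 is a 1.5-fold lower number from compound 1 to compound 3 (0.17 log units; within the scatter).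

Compound 4 `Nc1cc(N)c2nc(-c3ccccc3)c(Oc3ccc(F)cc3)nc2c1` differs from compound 2 by 4-fluorophenoxy in place of (4-fluorobenzyl)amino on an aromatic carbon. For the measured compounds named here, the measured steps all concern the substituent pattern on the pendant aromatic ring and leave the linker untouched, so none of them bears directly on this change; they show only that the group hanging from the core matters by a large amount, as in the step of a 12-fold lower number from compound 1 to compound 2 (1.09 log units; beyond the scatter). Going by the values given here, for the exchange of the linker itself there is no measured precedent, and the expectation can only be cautious.

Compound 4 is therefore expected to land somewhat weaker than compound 2, with a step of about a 3.2-fold higher number from compound 2 to compound 4 (0.50 log units; beyond the scatter) in this assay, and the estimate for compound 4 is 10000 nM, within a range of 2000 nM to 50000 nM.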

Compound 4, concentration for total growth inhibition: 79400 nM
Compound 4: middle estimate off by 7.9-fold (0.90 log units), on the low side; the measured number lies above the stated range.
By their numbers in this assay, from the lowest: compound 2; then compounds 3 and 1 (each within the scatter of the next); then compound 4.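

In this assay, putting 4-fluorophenoxy in place of (4-fluorobenzyl)amino, on the aromatic carbon next to the ring nitrogen, gives a 25-fold higher number from compound 2 to compound 4 (1.40 log units; beyond the scatter), so the link between the shared core and the 4-fluorophenyl ring counts for a great deal in this pair, even though the ring itself is kept. The earlier steps shown here changed only the substituents on the pendant ring and left the amino link untouched, whereas this change removes both the nitrogen, with its hydrogen-bond donor, and the saturated chain carbon, and brings in an oxygen. The result therefore shows the effect of the whole exchange and not of any one atom, and nothing shown accounts for the size of the step.

A benzyloxy group would keep the chain carbon with oxygen in place of the nitrogen, and an anilino group would keep the nitrogen without the chain carbon, so the compounds shown do not separate these two parts of the change. From the compounds shown here alone, it also remains open whether a phenoxy link would give a similar step with the 4-methoxyphenyl ring of compound 3 or the 3,4-dimethoxyphenyl ring of compound 1.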